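This account rests on a few compounds, and the source may have more. Where it says the series, first, only, none or still open, it means among the compounds named here.

Measured compounds in a functional assay on the whole organism for inhibition, with Rattus norvegicus as the target, read by cytopathic effect and paw edema, at a dose of 100 mg/kg by the oral route; a higher number here means more inhibition at the dose given (going by the name of the read-out), a lower number less inhibition:
compound 1 `CN(C)CCNC(=O)c1c(O)c2cccnc2n(-c2ccccc2)c1=O`: 18.4%
compound 2 `O=C(Nc1ccc(Cl)cc1)c1c(O)c2cccnc2n(-c2ccccc2)c1=O`: 2.5%
compound 3 `Cc1ccccc1NC(=O)c1c(O)c2cccnc2n(-c2ccccc2)c1=O`: 9.8%

Compound 1 stands highest of the three numbers. Compound 3 is nearest to it, and the step of a number 8.6 percentage points lower from compound 1 to compound 3 (within the scatter) stays within the scatter, so no order between compound 1 and compound 3 can be read. Compound 2 is furthest, and the step of a number 15.9 percentage points lower from compound 1 to compound 2 (beyond the scatter) lies beyond the scatter. Between compound 2 and compound 3 the step of a number 7.3 percentage points higher from compound 2 to compound 3 (within the scatter) is again within the scatter.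

Compound 4 `COc1ccccc1NC(=O)c1c(O)c2cccnc2n(-c2ccccc2)c1=O` is not yet measured. It differs from compound 1 by 2-methoxyphenyl in place of 2-(dimethylamino)ethyl on an amide-type nitrogen. The two measured steps from compound 1 are of the same kind: each puts an aryl group in place of the 2-(dimethylamino)ethyl group on the amide-type nitrogen, and each lowers the number, one within the scatter and one beyond it. The step to compound 4 is therefore expected to run downward as well, of a size between those two, so that the expected step is a number 11.4 percentage points lower from compound 1 to compound 4 (beyond the scatter). Compound 4 is estimated at 7%, with a range from 0% to 18%.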

Compound 4, a percentage reported as inhibition, in the whole organism at one dose (the size of the read-out at that dose, not a potency): -10.1%
For compound 4 the middle estimate is 17.1 percentage points above the measured one, outside the stated range (below it).
By their numbers in this assay, from the lowest: compound 4; then compounds 2, 3 and 1 (each within the scatter of the next, the first and the last beyond it).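

In this assay the aryl groups on the amide-type nitrogen no longer read as one class: methoxy in place of methyl on an aromatic carbon gives a number 19.9 percentage points lower from compound 3 to compound 4 (beyond the scatter) as a single small change, whereas compound 2 and compound 3 stood within the scatter of each other. The 2-methoxyphenyl group also separates from 4-chlorophenyl, with a number 12.6 percentage points lower from compound 2 to compound 4 (beyond the scatter) on that swap, and from 2-(dimethylamino)ethyl, with a number 28.5 percentage points lower from compound 1 to compound 4 (beyond the scatter) on that swap, so compound 4 is the lowest of the series, beyond the scatter from all three others. No measured evidence bears on this drop.

On these data alone, whether hydroxy or ethoxy in place of the methoxy of compound 4 would keep the number this low stays open. Also open, as far as these compounds go, is how a longer chain ending in a dimethylamino group on the amide-type nitrogen would compare with compound 1.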